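The compounds below may be only part of what the source reports. "The series", "measured", "known", "first", "only" and "open" are said of these compounds alone.

The measured compounds:

Compound 1, `Cc1ccc(NCc2cn(-c3ccccc3)nc2-c2ccc(Cl)cc2)cc1`, gives > 100000 nM in an ADME assay on MDBK cells (Bos taurus) for cytotoxicity, read by MTT assay, with a stated time of 72 h (a higher number here means that more compound is tolerated, a lower number that less compound is tolerated), which is a limit of the assay.
Compound 2, `Cc1ccc(NCc2cn(-c3ccccc3)nc2-c2ccc(C(F)(F)F)cc2)cc1`, gives > 100000 nM in this assay, again a limit.
Compound 3, `Cc1ccc(-c2nn(-c3ccccc3)cc2CNc2ccc(C(F)(F)F)cc2)cc1`, gives > 100000 nM in this assay, also a limit.

All three values therefore sit at the same point, (the limit of > 100000 nM in this assay, at which 3 of the 3 values shown sit), and none of them is a number. Compound 2 and compound 1 differ by one change, (chloro in place of trifluoromethyl on an aromatic carbon), and the step this change makes in this assay is a step that the two limits leave unreadable from compound 2 to compound 1. Compound 3 carries the same atoms as compound 2 joined differently; the difference between the two cores is not broken down here.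

The unmeasured compound 4, `Cc1ccc(-c2nn(-c3ccccc3)cc2CNc2ccc(Cl)cc2)cc1`, differs from compound 3 by chloro in place of trifluoromethyl on an aromatic carbon. The place in which the change sits is the same in both pairs, so it is the same change made on the core of compound 3 rather than on that of compound 2. Among the compounds with values here, because the only example of this change, from compound 2 to compound 1, is unreadable between two limits in this assay, and because the limit of > 100000 nM in this assay, at which 3 of the 3 values shown sit, holds every value shown, the expectation for compound 4 is that it, too, is tolerated up to the limit. The step expected from compound 3 to compound 4 in this assay is a number no higher from compound 3 to compound 4 (the limit leaves the size open), which rests only on (the limit of > 100000 nM in this assay, at which 3 of the 3 values shown sit). Compound 4 is accordingly estimated at 100000 nM, with a range of 30000 nM to 300000 nM.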

Compound 4, half-maximal cytotoxic concentration: > 100000 nM
Compound 4 was reported as a limit (the forecaster's own chance of this, stated with the estimate: 85%); the middle value lies on the limit itself.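

Compound 4 gives > 100000 nM in this assay, which is a limit of the assay. Compound 3 stands at a limit too, so no step can be read between compound 3 and compound 4. The compounds shown leave open what concentration of any of them is cytotoxic, and whether the chloro or trifluoromethyl group or the core makes any difference, as every value rests at one point: the limit of > 100000 nM in this assay, at which 4 of the 4 values shown sit.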